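Fluoro on the saturated ring carbon of compound 2

The compounds below may be only part of what the source reports. "The series", "measured", "known", "first", "only" and "open" are said of these compounds alone.

Of the compounds shown here, two have been measured in a functional assay on NCI-H460 cells (Homo sapiens) for cytotoxicity, read by MTT assay; a lower number here means a stronger inhibitor, a higher number a weaker inhibitor. Compound 1 `C/C=C/C(=O)OCC1=CC(O)CCC1=O` gives 10000 nM in this assay. Compound 2 `C/C=C/C(=O)OCC1=C[C@@H](O)[C@H](O)CC1=O` gives 158000 nM in this assay, the highest of the two numbers and beyond the scatter from compound 1. Among the compounds with values here, compound 3 `C/C=C/C(=O)OCC1=C[C@@H](O)[C@H](O)[C@H](F)C1=O` carries fluoro in place of hydrogen on a saturated ring carbon; no step between measured compounds bears on this change, so any expectation rests on compound 2 alone. The step from compound 2 to compound 3 in this assay is expected to be small, a 1.6-fold lower number from compound 2 to compound 3 (0.20 log units; within the scatter), with no clear direction beyond the scatter. Compound 3 is accordingly estimated at 100000 nM, within 30000 nM to 350000 nM.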

Compound 3, half-maximal inhibitory concentration: > 200000 nM
Compound 3: no number, only a limit (the forecaster's own chance of this, stated with the estimate: 10%); middle value at least 2.0-fold (0.30 log units) away from the limit.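

Compound 3 gives only a limit in this assay, not a number: the limit of > 200000 nM in this assay, at which 1 of the 3 values shown sits. The change reads as an at least 1.2-fold higher number from compound 2 to compound 3 (0.10 log units; that floor lies within the scatter), so fluoro in place of hydrogen on this saturated ring carbon, next to the ring atom that bears a hydroxy group, shows no lower number in this assay. Since that floor lies within the scatter, the size of the step remains unresolved, and it may be small or large.

As far as these compounds go, whether chloro, methoxy or an amine on this carbon would give a lower number remains open. So does the effect of the opposite stereochemistry at this carbon.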